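The source may hold more compounds than are shown below. What is called first, only, known or untested is meant among the compounds shown, and "the series" means these compounds.

Measured compounds:
compound 1 `CC(Nc1nc(N)nc2ccc(-c3cnn(C4CCNCC4)c3)cc12)c1c(Cl)ccc(F)c1Cl`, 5100 nM
compound 2 `CC(Nc1ncnc2ncc(-c3cnn(C4CCNCC4)c3)cc12)c1c(Cl)ccc(F)c1Cl`, 13500 nM
compound 3 `CC(Nc1nc(N)nc2ccc(-c3cnn(C)c3)cc12)c1c(Cl)ccc(F)c1Cl`, 7120 nM

Three compounds were tested in a functional assay on BT-474 cells (Homo sapiens) for antiproliferative activity, read by MTT assay, with a stated time of 72 h; on this read-out lower numbers stand for stronger inhibition and higher numbers for weaker inhibition. Compound 1 and compound 3 share one core and differ in a single place: methyl in place of piperidin-4-yl on an aromatic nitrogen. That change gave a 1.4-fold higher number from compound 1 to compound 3 (0.14 log units; within the scatter). Compound 2 carries a different core; how the two cores differ is not broken down here. Among the three, compound 2 gives the highest number, and its gap to compound 1 is beyond the scatter, while its gap to compound 3 is not.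

Compound 4 `CC(Nc1ncnc2ncc(-c3cnn(C)c3)cc12)c1c(Cl)ccc(F)c1Cl` has not yet been measured. It relates to compound 2 as compound 3 relates to compound 1: methyl in place of piperidin-4-yl on an aromatic nitrogen. The place of the change is the same in both pairs, so it is the same change. Because the earlier step was a 1.4-fold higher number from compound 1 to compound 3 (0.14 log units; within the scatter), a step of similar size is expected from compound 2 to compound 4, a 1.4-fold higher number from compound 2 to compound 4 (0.15 log units; within the scatter), resting on that single pair alone. For compound 4 the estimated value in this assay is 19000 nM, expected between 9000 nM and 40000 nM.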

Compound 4, half-maximal inhibitory concentration: > 100000 nM
Compound 4 gave a limit, no number (the forecaster's own chance of this, stated with the estimate: 20%); at least 5.2-fold (0.72 log units) between middle value and limit.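

In this assay, methyl in place of piperidin-4-yl gave an at least 7.4-fold higher number from compound 2 to compound 4 (0.86 log units; beyond the scatter), so the change did not carry over in size from one core to the other: the same change on two cores in this assay, a 1.4-fold higher number (0.14 log units; within the scatter) from compound 1 to compound 3 and an at least 7.4-fold higher number (0.86 log units; beyond the scatter) from compound 2 to compound 4, at least 5.3-fold (0.72 log units) apart, beyond the scatter of two such steps. Compound 4 gives > 100000 nM, which is a limit of the assay and not a number. As far as these compounds go, the full size of the step on the core of compound 2 stays unknown, and one pair on each core does not show how the change would behave on a further core.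

The compounds shown leave open which part of piperidin-4-yl matters on the core of compound 2. A cyclohexyl group or an open-chain amine on that aromatic nitrogen could separate the ring from its nitrogen.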